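Trifluoromethoxy for trifluoromethyl in a pentafluorosulfanyl anilide series

The source may report more compounds than this note shows. Statements on the series, on what has been measured and on what is new or still open speak of the compounds shown alone.

Compound 1 `CC(O)(CSc1ccc(C(F)(F)F)cc1)C(=O)Nc1cccc(S(F)(F)(F)(F)F)c1` and compound 2 `CC(O)(CSc1ccc(OC(F)(F)F)cc1)C(=O)Nc1cccc(S(F)(F)(F)(F)F)c1` share one core; compound 3 `CC(O)(COc1ccc(C(F)(F)F)cc1)C(=O)Nc1cccc(S(F)(F)(F)(F)F)c1` and compound 4 `CC(O)(COc1ccc(OC(F)(F)F)cc1)C(=O)Nc1cccc(S(F)(F)(F)(F)F)c1` share another. The difference between the two cores is not broken down here. In a functional assay on VCaP cells (Homo sapiens) for antiproliferative activity, read by propidium iodide staining, with a stated time of 96 h (a higher number here means a weaker inhibitor, a lower number a stronger inhibitor), compound 1 gives 27300 nM and compound 2 gives 28500 nM; the change between them, (trifluoromethoxy in place of trifluoromethyl on an aromatic carbon), made a step of a 1.0-fold higher number from compound 1 to compound 2 (0.02 log units; within the scatter). In this assay compound 3 gives 13300 nM, the lowest number of the three measured and beyond the scatter from each of the other two. Compound 4 carries the same change as the earlier pair, (trifluoromethoxy in place of trifluoromethyl on an aromatic carbon), at a place described in the same words. The step from compound 3 to compound 4 is expected to be a 1.1-fold higher number from compound 3 to compound 4 (0.02 log units; within the scatter), set beside the earlier step because a 1.0-fold higher number from compound 1 to compound 2 (0.02 log units; within the scatter) left the number essentially where it stood; with a single prior instance the range is kept broad. Compound 4 is estimated at 14000 nM in this assay, between 7000 nM and 28000 nM.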

Compound 4, half-maximal inhibitory concentration: 20200 nM
Beside the measured number, compound 4's estimate is 1.4-fold (0.16 log units) below it; low and high end bracket the measured number.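

In this assay, the second core takes the exchange of trifluoromethyl for trifluoromethoxy with a step of a 1.5-fold higher number from compound 3 to compound 4 (0.18 log units; within the scatter), so on this core too the change does not move the number beyond the scatter. The steps on the two cores show no difference that can be read: the same change on two cores in this assay, a 1.0-fold higher number (0.02 log units; within the scatter) from compound 1 to compound 2 and a 1.5-fold higher number (0.18 log units; within the scatter) from compound 3 to compound 4, 1.5-fold (0.16 log units) apart, within the scatter of two such steps. Going by these compounds alone, this supports carrying the exchange between these two cores in this one assay as a change with little read-out effect, but it rests on only two matched pairs and does not show that the same would hold on any other core or in any other assay.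

The compounds shown leave open how groups other than these two, such as a nitrile or a chlorine atom, would behave on that aromatic carbon para to a large group. They also leave open whether the steps would stay alike on either core if the pentafluorosulfanyl group gave way to a nitrile.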